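Hydroxy Loss in a Small Set of Phenolic Hydrazides

This account rests on a few compounds, and the source may have more. Where it says the series, first, only, none or still open, it means among the compounds named here.

Three compounds have been measured in a functional assay (Mus musculus, strain BALB/C) for inhibition, read by MTT assay, with stated times of 24 h and 72 h; a higher number here means a weaker inhibitor, a lower number a stronger inhibitor:

Compound 1 `Cc1ccc(C(=O)N/N=C/c2ccccc2)c(O)c1` gives 53900 nM.
Compound 2 `Cc1ccc(C(=O)N/N=C/c2ccccc2O)c(O)c1` gives 1020 nM.
Compound 3 `Cc1ccc(C(=O)N/N=C/c2cc(Br)ccc2O)c(O)c1` gives 1090 nM.

Compound 2 and compound 3 share a core that differs by bromo in place of hydrogen on an aromatic carbon. This shows as a 1.1-fold higher number from compound 2 to compound 3 (0.03 log units; within the scatter), so the two numbers cannot be told apart.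

Compound 1 comes from compound 2 by hydrogen in place of hydroxy on an aromatic carbon. For the measured compounds named here, this change is the one large step in the set: a 53-fold higher number from compound 2 to compound 1 (1.72 log units; beyond the scatter).

Compound 4 `Cc1ccc(C(=O)N/N=C/c2cccc(Br)c2)c(O)c1` comes from compound 3 by hydrogen in place of hydroxy on an aromatic carbon. Its place differs from the place in compound 1 in one respect: in compound 3 the spot is also para to a bromo group. It is therefore the same kind of change, not the same change.

Because a 53-fold higher number from compound 2 to compound 1 (1.72 log units; beyond the scatter) was large, and because a 1.1-fold higher number from compound 2 to compound 3 (0.03 log units; within the scatter) shows that the bromo group hardly altered the number, compound 4 is expected to show a step of similar size: a 46-fold higher number from compound 3 to compound 4 (1.66 log units; beyond the scatter). Compound 4 is thus estimated at 50000 nM, expected between 15000 nM and 160000 nM.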

Compound 4, half-maximal inhibitory concentration: 28300 nM
Compound 4: the middle estimate sits 1.8-fold (0.25 log units) above what was measured; low and high end bracket the measured number.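

Hydrogen in place of hydroxy is again a large step on the core that carries the bromo group in this assay, a 26-fold higher number from compound 3 to compound 4 (1.41 log units; beyond the scatter), and it agrees with the earlier step: the same change on two cores in this assay, a 53-fold higher number (1.72 log units; beyond the scatter) from compound 2 to compound 1 and a 26-fold higher number (1.41 log units; beyond the scatter) from compound 3 to compound 4, 2.0-fold (0.31 log units) apart, within the scatter of two such steps

Bromo in place of hydrogen likewise stays within the scatter without the hydroxy group, a 1.9-fold lower number from compound 1 to compound 4 (0.28 log units; within the scatter), and this agrees with the earlier bromo step: the same change on two cores in this assay, a 1.1-fold higher number (0.03 log units; within the scatter) from compound 2 to compound 3 and a 1.9-fold lower number (0.28 log units; within the scatter) from compound 1 to compound 4, 2.0-fold (0.31 log units) apart, within the scatter of two such steps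

Across these four compounds, the hydroxy step therefore carries from one core to the other and the bromo group hardly alters it, but this rests on only two pairs in one assay and does not show that the step would hold on any other core or explain why it is large.

The compounds shown leave open whether a methoxy group, an amine or a fluoro group in place of the hydroxy group would keep the number close to that of compound 2. They also leave open whether a chloro group or a longer chain in place of the bromo group would leave the number as little altered.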